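Swapping a sulfonamide for an amide on a three-carbon linker

A few compounds are considered here, and "the series" means these few. Any claim that something is new, unique, unknown or untested is made for them only; others in the source may bear on it.

Measured compounds:
- compound 1 `O=S(=O)(NCCCNc1nccc(-c2c(-c3cccc(F)c3)nc3sccn23)n1)c1cccc(F)c1`: 8550 nM
- compound 2 `O=C(NCCNc1nccc(-c2c(-c3cccc(F)c3)nc3sccn23)n1)c1c(F)cccc1F`: 11400 nM
- compound 3 `Cc1ccc(C(=O)NCCNc2nccc(-c3c(-c4cccc(F)c4)nc4sccn34)n2)cc1`: 18800 nM

All three share a core and differ only in the group at the far end of a short chain. For the measured compounds named here, in a functional assay on SK-MEL-28 cells (Homo sapiens) for cytotoxicity, read by MTT assay (a higher number here means a weaker inhibitor, a lower number a stronger inhibitor), compound 1 gives the lowest of the three numbers; compound 2 lies closest to it, and compound 3 furthest, with a 2.2-fold higher number from compound 1 to compound 3 (0.34 log units; beyond the scatter) being the only step beyond the scatter. The step of a 1.3-fold higher number from compound 1 to compound 2 (0.12 log units; within the scatter) stays within it, as does a 1.6-fold higher number from compound 2 to compound 3 (0.22 log units; within the scatter).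

Compound 4 `O=C(NCCCNc1nccc(-c2c(-c3cccc(F)c3)nc3sccn23)n1)c1ccc(F)cc1` has not yet been measured. Compared with compound 1 it keeps the three-carbon chain and changes only the terminal group: (4-fluorophenyl)carbonyl in place of (3-fluorophenyl)sulfonyl on an amine nitrogen.

Going by the values given here, two measured steps bear on this change, since both replace the sulfonamide of compound 1 with a carbonyl amide, though each also shortens the chain: a 1.3-fold higher number from compound 1 to compound 2 (0.12 log units; within the scatter) and a 2.2-fold higher number from compound 1 to compound 3 (0.34 log units; beyond the scatter). Both moved to a higher number, one within the scatter and one modestly beyond it. A similar small shift upward is therefore expected for compound 4, estimated as a 1.4-fold higher number from compound 1 to compound 4 (0.15 log units; within the scatter), with a real chance that it lands within the scatter of compound 1. The expected value for compound 4 in this assay is 12000 nM, with a likely range from 5000 nM to 30000 nM.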

Compound 4, half-maximal inhibitory concentration: > 20000 nM
Compound 4: only a limit was reported; the forecaster's own chance of this, stated with the estimate: 10%; middle value at least 1.6-fold (0.22 log units) away from the limit.
By their numbers in this assay, from the lowest: compounds 1, 2 and 3 (each within the scatter of the next, the first and the last beyond it). At a limit, above all of these: compound 4.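

In this assay, compound 4 gives only a limit, > 20000 nM. With the chain of compound 1 kept, (4-fluorophenyl)carbonyl in place of (3-fluorophenyl)sulfonyl on the amine nitrogen gives an at least 2.3-fold higher number from compound 1 to compound 4 (0.36 log units; beyond the scatter), so a change confined to the terminal group is enough to move the number beyond the scatter, whereas each earlier step away from compound 1 also altered the chain. Against the two amides on the shorter chain, the steps are an at least 1.0-fold higher number from compound 3 to compound 4 (0.02 log units; that floor lies within the scatter) and an at least 1.7-fold higher number from compound 2 to compound 4 (0.24 log units; that floor lies within the scatter); these are floors only, so neither step can be read as a real gap, and the effect of chain length among the amides remains unsettled.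

The swap also moves the fluorine and replaces the sulfonyl with a carbonyl, so the compounds shown cannot separate the two changes; a (3-fluorophenyl)carbonyl or a (4-fluorophenyl)sulfonyl on this same chain would do that. Nor do they show how this position responds to a terminal group without an aromatic ring, such as a simple acetyl, or to a longer chain.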